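This account rests on a few compounds, and the source may have more. Where it says the series, first, only, none or still open, it means among the compounds named here.

Measured compounds:
Compound 1, `O=C(/C=C/c1ccc(CN2C(=O)/C(=C3\Nc4ccccc4\C3=N/O)c3cc(Cl)ccc32)cc1)NO`, in a functional assay on PC-3 cells (Homo sapiens) for cytotoxicity, read by colorimetric assay (a higher number here means a weaker inhibitor, a lower number a stronger inhibitor), gives 60 nM.
Compound 2, `COc1ccc2c(c1)/C(=C1/Nc3ccccc3/C1=N\O)C(=O)N2Cc1ccc(/C=C/C(=O)NO)cc1`, in this assay gives 30 nM.

Compound 2 has the lower of the two numbers, but the step of a 2.0-fold lower number from compound 1 to compound 2 (0.30 log units; within the scatter) lies within the scatter, so on these data compound 1 and compound 2 cannot be told apart. Compound 3, `O=C(/C=C/c1ccc(CN2C(=O)/C(=C3\Nc4ccccc4\C3=N/O)c3cc(F)ccc32)cc1)NO`, has not yet been measured in this assay. It differs from compound 2 in one place: fluoro in place of methoxy on an aromatic carbon. Going by the values given here, the only measured step that bears on this change is a 2.0-fold lower number from compound 1 to compound 2 (0.30 log units; within the scatter), which exchanged chloro for methoxy at this same aromatic carbon and stayed within the scatter. Compound 1 carries chloro at this carbon, and fluoro, like chloro, is a halogen, so compound 3 is expected to land near compound 1 and compound 2 alike, with no step beyond the scatter in either direction. The step of a 1.7-fold higher number from compound 2 to compound 3 (0.22 log units; within the scatter) is the change the estimate implies. For compound 3 in this assay the estimate is 50 nM, with a range from 20 nM to 130 nM.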

Compound 3, half-maximal inhibitory concentration: 50 nM
Compound 3: the middle estimate sits on the measured number at the digits printed, within the range that was stated.
By their numbers in this assay, from the lowest: compounds 2, 3 and 1 (each within the scatter of the next).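

With fluoro at this aromatic carbon, the position has now carried three different groups in this assay, and both new steps stay within the scatter: a 1.7-fold higher number from compound 2 to compound 3 (0.22 log units; within the scatter), and a 1.2-fold lower number from compound 1 to compound 3 (0.08 log units; within the scatter). The earlier compounds shown here offered a single exchange, chloro for methoxy, whereas the series now adds a second exchange of methoxy for a halogen and an exchange of one halogen for another, and none of the three can be told apart, so across these three groups the identity of the substituent at this carbon makes no resolvable difference to the number. Nothing at hand speaks to the reason for this, and the result is recorded here only as a measured observation.

The compounds shown leave open whether the same holds for groups of another kind on this aromatic carbon, such as an amine, a carboxylic acid or a longer alkoxy chain. They also leave open whether fluoro, chloro and methoxy would remain indistinguishable at another carbon of the same ring, or in a read-out other than this assay.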